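Replacing a bromobenzyl amine with piperidine on the amide ring

The source may hold more compounds than are shown below. What is called first, only, known or untested is meant among the compounds shown, and "the series" means these compounds.

Measured compounds:
Compound 1, `NS(=O)(=O)Oc1ccc2c(c1)CN(C(=O)c1cccc(N3CCC(Cc4ccccc4)CC3)c1)CC2`: 41.9%
Compound 2, `CN(CCCN1CCCCC1)c1ccc(C(=O)N2CCc3ccc(OS(N)(=O)=O)cc3C2)cc1`: 40.7%
Compound 3, `CCN(Cc1cccc(Br)c1)c1ccc(C(=O)N2CCc3ccc(OS(N)(=O)=O)cc3C2)cc1`: 97.2%

Three compounds share the same core and differ only in the amine attached to the benzoyl ring. In an assay on HEK293 cells for inhibition of Steryl-sulfatase (Homo sapiens), tested at 1 uM (a higher number here means a stronger effect of the compound at the concentration tested, a lower number a weaker effect), compound 3 gives 97.2%, the highest of the three numbers; compound 1 gives 41.9% and compound 2 gives 40.7%, both far lower, and the gaps to compound 3 lie beyond the usual scatter.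

Compound 4, `NS(=O)(=O)Oc1ccc2c(c1)CN(C(=O)c1ccc(N3CCCCC3)cc1)CC2`, has not yet been measured. Its change from compound 3 is piperidin-1-yl in place of (3-bromobenzyl)(ethyl)amino on an aromatic carbon.

For the measured compounds named here, the one measured step that bears on this is a number 56.5 percentage points higher from compound 2 to compound 3 (beyond the scatter), where the amine at the same place changed and the whole gain was tied to the (3-bromobenzyl)(ethyl)amino group. Compound 4 gives up that group for piperidin-1-yl, a smaller ring amine, and compound 1, which carries a ring amine at a different place, sits near compound 2. The author therefore expects a large downward step, a number 52.2 percentage points lower from compound 3 to compound 4 (beyond the scatter), back toward the level of compound 1 and compound 2. The estimate for compound 4 in this assay is 45%, with a range from 25% to 70%.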

Compound 4, a percentage reported as inhibition, at one concentration (the size of the read-out at that concentration, not a potency): 38.3%
For compound 4 the middle estimate is 6.7 percentage points above the measured one; measured number inside the range.
By their numbers in this assay, from the lowest: compounds 4, 2 and 1 (each within the scatter of the next); then compound 3.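

In this assay, the change to piperidin-1-yl gives a number 58.9 percentage points lower from compound 3 to compound 4 (beyond the scatter), so a second, different amine on this aromatic carbon, para to a large group, also falls far short of the (3-bromobenzyl)(ethyl)amino group. The step of a number 2.4 percentage points lower from compound 2 to compound 4 (within the scatter) adds that piperidin-1-yl and methyl(3-(piperidin-1-yl)propyl)amino cannot be told apart at this position, so among these three groups the high read-out goes with (3-bromobenzyl)(ethyl)amino alone. No measurement shown here accounts for this difference between the groups.

The compounds shown leave open which part of the (3-bromobenzyl)(ethyl)amino group the high read-out goes with: the bromine, the benzyl ring, the ethyl chain or the way these sit together on one nitrogen. An unsubstituted benzyl group, a chlorine in place of the bromine, a methyl in place of the ethyl, or an ether oxygen in place of the linking nitrogen would each separate one of these parts from the others.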